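The source may report more compounds than this note shows. Statements on the series, on what has been measured and on what is new or still open speak of the compounds shown alone.

In a functional assay on OVCAR-5 cells (Homo sapiens) for inhibition, read by sulforhodamine B assay, with a stated time of 48 h (a higher number here means a weaker inhibitor of growth, a lower number a stronger inhibitor of growth), the measured compounds stand as follows:

- compound 2 `Nc1cc(N)c2nc(-c3ccccc3)c(NCc3ccc(Cl)c(Cl)c3)nc2c1` gives 24000 nM
- compound 3 `CCOC(=O)[C@H](CCC(=O)O)NC(=O)c1ccc(Oc2nc3cc(N)cc(N)c3nc2-c2ccccc2)cc1` gives 79400 nM
- compound 1 `CCOC(=O)[C@H](CCC(=O)O)NC(=O)c1ccc(CNc2nc3cc(N)cc(N)c3nc2-c2ccccc2)cc1` gives only < 100000 nM, a limit of this assay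

Compound 2 holds the lowest of the two real numbers, and its gap to compound 3 lies beyond the usual scatter. For compound 1 there is no number, only the limit described in the limit of < 100000 nM in this assay, at which 1 of the 3 values shown sits.

Compound 4 `COc1ccc(CNc2nc3cc(N)cc(N)c3nc2-c2ccccc2)cc1` is compound 2 with one change: 4-methoxyphenyl in place of 3,4-dichlorophenyl on a saturated chain carbon bound to a nitrogen on an aromatic ring. No pair of measured compounds differs in just this way, so the size of this step is not shown anywhere among the measured values. With the 3,4-dichlorophenyl group gone and the 4-methoxyphenyl group in its place, a moderate move toward a higher number, beyond the scatter, is expected, though a result within the scatter of compound 2 cannot be ruled out. Compound 4 is therefore estimated at 50000 nM, with a range of 15000 nM to 150000 nM. The expected step of a 2.1-fold higher number from compound 2 to compound 4 (0.32 log units; beyond the scatter) carries this estimate, with a fair chance that this assay reports only a limit for compound 4.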

Compound 4, concentration for 50% growth inhibition: 20900 nM
Estimate against measurement, compound 4: 2.4-fold (0.38 log units) above, and the stated range covers the measured number.
By their numbers in this assay, from the lowest: compounds 4 and 2 (each within the scatter of the next); then compound 3.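

Among the earlier compounds, no pair differed in just one place, so this position had no measured step. In this assay, replacing 3,4-dichlorophenyl with 4-methoxyphenyl on a saturated chain carbon bound to a nitrogen on an aromatic ring gives a 1.1-fold lower number from compound 2 to compound 4 (0.06 log units; within the scatter), so the two compounds cannot be told apart. This position therefore accepts either group in this assay, although the 4-methoxyphenyl group brings a hydrogen-bond acceptor that the 3,4-dichlorophenyl group lacks, and nothing measured here bears on why the two compounds match.

The compounds shown rest on these two groups alone, so a single generalisation about this position cannot be drawn from them. As far as these compounds go, whether an unsubstituted phenyl, a 4-aminophenyl or a 4-carboxyphenyl group would also match compound 2 remains open.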